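Swapping the aryl group on the shared core

The source may report more compounds than this note shows. Statements on the series, on what has been measured and on what is new or still open speak of the compounds shown alone.

Compound 2 `COc1cc(C2=NN(C(C)=O)C(c3cccc(F)c3)O2)cc(OC)c1OC` stands lowest of the two compounds measured in a functional assay on PC-3 cells (Homo sapiens) for antiproliferative activity, read by MTT assay, tested at 1 uM; on this read-out higher numbers stand for a stronger effect at the one concentration tested and lower numbers for a weaker effect: compound 2 gives 16.5%, while compound 1 `COc1ccc(OC)c(C2OC(c3cc(OC)c(OC)c(OC)c3)=NN2C(C)=O)c1` gives 37.2%. Compound 3 `COc1cc(C2=NN(C(C)=O)C(c3ccc(Cl)c([N+](=O)[O-])c3)O2)cc(OC)c1OC` has not been measured; it differs from compound 2 by 4-chloro-3-nitrophenyl in place of 3-fluorophenyl on a saturated ring carbon. For the measured compounds named here, the only measured step also exchanges the aryl group on that saturated ring carbon, a number 20.7 percentage points lower from compound 1 to compound 2 (beyond the scatter), showing that such an exchange can move this assay beyond the scatter, yet no measured compound carries a chloro or nitro group. Compound 3 is therefore estimated at 24%, with a range of 6% to 48%. This corresponds to an expected step of a number 7.5 percentage points higher from compound 2 to compound 3 (within the scatter).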

Compound 3, a percentage reported as inhibition, at one concentration (the size of the read-out at that concentration, not a potency): 43.3%
The estimate for compound 3 lay 19.3 percentage points below the measured number, within the range that was stated.
By their numbers in this assay, from the lowest: compound 2; then compounds 1 and 3 (each within the scatter of the next).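

In this assay the exchange on the saturated ring carbon now also moves upward: 4-chloro-3-nitrophenyl in place of 3-fluorophenyl gives a number 26.8 percentage points higher from compound 2 to compound 3 (beyond the scatter) at this position. Against 2,5-dimethoxyphenyl the same group gives a number 6.1 percentage points higher from compound 1 to compound 3 (within the scatter) and so two differently substituted aryl groups read alike here, with 3-fluorophenyl the one that stands apart. Nothing at hand explains this difference.

The compounds shown leave open whether the chloro or the nitro group carries the step. They also leave open how a phenyl ring bearing an amine or a carboxylic acid would read here.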